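An expected half-life for compound 4

This account rests on a few compounds, and the source may have more. Where it says the series, first, only, none or still open, it means among the compounds named here.

Compound 1 `CCn1ncc2c(F)cc(-c3ccc(C(CC)(CC)c4ncn(C)n4)c(=O)[nH]3)cc21`: in an ADME assay on microsomes from liver (Rattus norvegicus) for metabolic stability (a lower number here means that the compound disappears faster, a higher number that the compound lasts longer), compound 1 gives > 3 h, which is a limit of the assay and not a number.
Compound 2 `CC(C)C(c1ccc(-c2ccc3cccc(F)c3c2)[nH]c1=O)N1CCNC1=O`: compound 2 gives 0.283 h.
Compound 3 `CCC(CC)(c1nnc[nH]1)c1ccc(-c2ccc3cc(F)cc(F)c3c2)[nH]c1=O`: compound 3 gives 1.26 h.

Within the data shown here, compound 2 stands lowest of the two numbers known here; compound 3 lies above it by a margin beyond the usual scatter. Compound 4 `Cc1c[nH]c(C(c2ccc(-c3ccc4cccc(F)c4c3)[nH]c2=O)C(C)C)n1` differs from compound 2 in one place: 4-methyl-1H-imidazol-2-yl in place of 2-oxoimidazolidin-1-yl on a saturated chain carbon bound to an aromatic carbon and a saturated chain carbon. Among the measured compounds shown here, no step between two measured compounds is available, so the size of this change can only be anticipated: in this assay a rise beyond the scatter is expected from compound 2 to compound 4. Compound 4 is therefore estimated at 0.6 h, within 0.2 h to 1.8 h. That expected change is a 2.1-fold higher number from compound 2 to compound 4 (0.33 log units; beyond the scatter), leaning on the higher value of compound 3 at 1.26 h.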

Compound 4, half-life: < 0.0667 h
Compound 4 was reported as a limit; the forecaster's own chance of this, stated with the estimate: 5%; at least 8.9-fold (0.95 log units) between middle value and limit.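

Among these compounds, compounds 2 and 4 give the first step at this position in this assay, and it is not neutral: 4-methyl-1H-imidazol-2-yl in place of 2-oxoimidazolidin-1-yl gives an at least 4.2-fold lower number from compound 2 to compound 4 (0.62 log units; beyond the scatter). So the group on this saturated chain carbon alone can move the half-life beyond the scatter. The full size of the step cannot be read, because compound 4 stands at a value that is a limit of the assay and not a number: the limit of < 0.0667 h in this assay, at which 1 of the 4 values shown sits.

The compounds shown leave open whether the step belongs to the aromatic ring or to its methyl. An unsubstituted 1H-imidazol-2-yl at this place would separate the two.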